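Swapping Methoxy for Fluoro in a Shared Amide Core

The source may hold more compounds than are shown below. What is called first, only, known or untested is meant among the compounds shown, and "the series" means these compounds.

Three measured compounds share one core and differ only in a single group on one aromatic ring. Compound 1 `O=C(Nc1cccc(-c2nc3ccccc3s2)c1)c1cnccc1Cl` carries hydrogen there; in an ADME assay on HEK293 cells (Homo sapiens) for inhibition, with a stated time of 72 h (a lower number here means that less compound is needed, a higher number that more compound is needed for the effect), compound 1 reaches only the limit of > 25000 nM, which is the edge of the assay and not a number. Compound 2 `Cc1ccc(-c2nc3ccccc3s2)cc1NC(=O)c1cnccc1Cl` carries methyl; in this assay compound 2 likewise gives only the limit > 25000 nM. Compound 3 `COc1ccc(-c2nc3ccccc3s2)cc1NC(=O)c1cnccc1Cl` carries methoxy; in this assay compound 3 also stops at the limit > 25000 nM. Because all three sit at the limit of > 25000 nM in this assay, at which 3 of the 3 values shown sit, the steps a step that the two limits leave unreadable from compound 1 to compound 2, a step that the two limits leave unreadable from compound 1 to compound 3 and a step that the two limits leave unreadable from compound 2 to compound 3 cannot be read in size or direction.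

Compound 4 `O=C(Nc1cc(-c2nc3ccccc3s2)ccc1F)c1cnccc1Cl` is not yet measured; the change from compound 3 is fluoro in place of methoxy on an aromatic carbon. For the measured compounds named here, no measured step bears on it with a readable size, since every change among compounds 1, 2 and 3 left the value at the limit. The expected step that the limit leaves unreadable from compound 3 to compound 4 therefore rests on the limits alone. Compound 4 is estimated at 40000 nM, with a range from 10000 nM to 200000 nM, most likely again reported only as a limit.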

Compound 4, half-maximal effective concentration: > 25000 nM
Compound 4 ended at the assay's limit; the forecaster's own chance of this, stated with the estimate: 85%; the middle value is on the limit's open side.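

In this assay compound 4 gives > 25000 nM, a limit and not a number. Its steps from compound 1, compound 2 and compound 3 therefore cannot be read in size or direction: the limit of > 25000 nM in this assay, at which 4 of the 4 values shown sit.

On these data alone, how far these four compounds truly differ, and whether any group at this place gives a readable value, stays open.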